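Swapping the Oxadiazole Attachment Point on a Ring Nitrogen

This account rests on a few compounds, and the source may have more. Where it says the series, first, only, none or still open, it means among the compounds named here.

Compound 1 `CC(C)OC(=O)N1CCN(c2ncc(OCc3ccncc3C#N)cn2)[C@H](C)C1` gives 77% in a functional assay on isolated protein with Glucose-dependent insulinotropic receptor (Mus musculus) as the target, read by HTRF and cAMP accumulation, with a stated time of 45 min; a higher number here means a larger maximal response, a lower number a smaller maximal response. Compound 2 `C[C@@H]1CN(c2ncc(F)cn2)CCN1c1ncc(OCc2ccncc2C#N)cn1` gives 63%, and compound 3 `C[C@@H]1CN(c2noc(C3CC3)n2)CCN1c1ncc(OCc2ccncc2C#N)cn1` gives 45%, the lowest of the three. The steps of a number 14 percentage points lower from compound 1 to compound 2 (beyond the scatter) and a number 32 percentage points lower from compound 1 to compound 3 (beyond the scatter) show that the group on this ring nitrogen shifts the maximal response; between the two ring groups the step is a number 18 percentage points lower from compound 2 to compound 3 (beyond the scatter). Compound 4 `C[C@@H]1CN(c2nc(C3CC3)no2)CCN1c1ncc(OCc2ccncc2C#N)cn1` keeps the same atoms, joined differently: 3-cyclopropyl-1,2,4-oxadiazol-5-yl in place of 5-cyclopropyl-1,2,4-oxadiazol-3-yl on an amine nitrogen in a ring. Among the compounds with values here, no measured step rearranges a ring in place, so the three steps only bracket how far the maximal response has moved at this position. A step within the scatter is expected for compound 4: a number 3 percentage points higher from compound 3 to compound 4 (within the scatter). Compound 4 is therefore estimated at 48%, between 30% and 66%.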

Compound 4, intrinsic activity: the largest response reached, in percent of the reference agonist's: 49%
Compound 4: the middle estimate sits 1 percentage points below what was measured; measured number inside the range.
By their numbers in this assay, from the lowest: compounds 3 and 4 (each within the scatter of the next); then compound 2; then compound 1.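

With a number 4 percentage points higher from compound 3 to compound 4 (within the scatter) in this assay, the way the oxadiazole is joined on this ring nitrogen does not separate the two isomers. Reversing the ring does not recover the maximal response seen with the other two groups, as a number 14 percentage points lower from compound 2 to compound 4 (beyond the scatter) and a number 28 percentage points lower from compound 1 to compound 4 (beyond the scatter) remain on this position. Nothing available explains these results.

The compounds shown leave open whether a methyl or a tert-butyl group in place of cyclopropyl on either oxadiazole would shift the maximal response.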